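The source may report more compounds than this note shows. Statements on the series, on what has been measured and on what is new or still open speak of the compounds shown alone.

For the measured compounds named here, compound 1 `CC(C)/C(=N\O)c1ccc(Sc2cc(F)cc(C3CCOCC3)c2)cc1` holds the higher of the two numbers known so far: in a functional assay (blood) for inhibition, with Homo sapiens as the target (a lower number here means a stronger inhibitor, a higher number a weaker inhibitor), compound 1 gives 300 nM, whereas compound 2 `CO[C@]1(c2cc(F)cc(Sc3ccc(/C(C)=N/OCC#N)cc3)c2)CCO[C@@H](C)C1` gives 40 nM, a gap beyond the usual scatter. Compound 3 `CN(C)/C(=N\O)c1ccc(Sc2cc(F)cc(C3CCOCC3)c2)cc1` awaits measurement. It differs from compound 1 in one place: dimethylamino in place of isopropyl on a carbon with a double bond to nitrogen. Going by the values given here, nothing among the measured compounds shows such an exchange, so the size of the coming step cannot be read from them. Compound 3 is expected to land near compound 1, with a step of a 1.3-fold higher number from compound 1 to compound 3 (0.12 log units; within the scatter) in this assay that may not exceed the scatter. The estimate for compound 3 is 400 nM, within 130 nM to 1200 nM.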

Compound 3, half-maximal inhibitory concentration in the Homo sapiens assay: 280 nM
For compound 3 the middle estimate is 1.4-fold (0.15 log units) above the measured one, within the range that was stated.
By their numbers in the Homo sapiens assay, from the lowest: compound 2; then compounds 3 and 1 (each within the scatter of the next).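

On a carbon with a double bond to nitrogen, dimethylamino in place of isopropyl leaves the result in the Homo sapiens assay within the scatter (a 1.1-fold lower number from compound 1 to compound 3 (0.03 log units; within the scatter)). The two compounds part clearly in a physicochemical assay for acid dissociation, where compound 1 gives 10.8 and compound 3 gives 14.1, so for this pair a large shift in how readily the proton is given up comes with no shift in inhibition beyond the scatter: (the measured acid dissociation constant of compound 1, 10.8, and of compound 3, 14.1, a number 3.30 log units higher (beyond the scatter)). A single pair cannot show whether this holds more widely. Going by these compounds, whether a ring amine such as morpholine, or a methoxy group, at this place would behave the same way remains open.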